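Five-membered ring swap at the saturated ring carbon

The compounds below may be only part of what the source reports. "The series", "measured", "known", "first", "only" and "open" are said of these compounds alone.

Measured in an ADME assay on microsomes from liver (Mus musculus) for metabolic stability, with a stated time of 30 min; on this read-out lower numbers stand for a less stable compound and higher numbers for a more stable compound:
compound 1, `Cc1nc(N2CCC(N3C(=O)CCC3=O)CC2)nc2ccc(NC(=O)/C=C/c3ccc(OC(F)(F)F)cc3)cc12`: 40%
compound 2, `Cc1nc(NCCCNS(C)(=O)=O)nc2ccc(NC(=O)/C=C/c3ccc(OC(F)(F)F)cc3)cc12`: 58%
compound 3, `Cc1nc(N2CCC(N3CCCC3=O)CC2)nc2ccc(NC(=O)/C=C/c3ccc(Cl)cc3)cc12`: 83%

Compound 1 gives the lowest of the three numbers. Compound 2 lies higher by an amount beyond the usual scatter, and compound 3 lies higher still, also beyond the scatter. Both differ from compound 1 in more than one place, so neither pair isolates a single change.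

Compound 4, `Cc1nc(N2CCC(N3CCN(C)C3=O)CC2)nc2ccc(NC(=O)/C=C/c3ccc(OC(F)(F)F)cc3)cc12`, differs from compound 1 in one place: 3-methyl-2-oxoimidazolidin-1-yl in place of 2,5-dioxopyrrolidin-1-yl on a saturated ring carbon. Going by the values given here, no measured pair shows this change on its own, so the direction rests on the three numbers alone. A small upward step, about at the edge of the scatter, is expected in this assay, namely a number 10 percentage points higher from compound 1 to compound 4 (within the scatter). Compound 4 is estimated at 50%, in a range from 30% to 75%.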

Compound 4, percent of the compound remaining: 94%
For compound 4 the middle estimate is 44 percentage points below the measured one; measured number above the stated range.
By their numbers in this assay, from the lowest: compound 1; then compound 2; then compound 3; then compound 4.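

In this assay, the swap to 3-methyl-2-oxoimidazolidin-1-yl gives a number 54 percentage points higher from compound 1 to compound 4 (beyond the scatter) as the only step shown that isolates a single change. A change confined to the five-membered ring on this saturated ring carbon can therefore shift the read-out by a large amount, with the rest of the molecule held constant. No measured data on hand account for the step. As far as these compounds go, whether an amine or a carboxylic acid on this carbon would give a similar number remains open. So does whether the swap would produce a comparable step in a compound carrying a different group at the far end of the molecule.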